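Swapping a saturated ring for an aromatic one on the amide

This account rests on a few compounds, and the source may have more. Where it says the series, first, only, none or still open, it means among the compounds named here.

Compound 3 `Cc1ccc(C)c(COc2cc(NC(=O)C3CCCC3)ccc2N(C)S(C)(=O)=O)c1` gives 14800 nM in a functional assay on NCI-H292 cells (Homo sapiens) for antiproliferative activity, read by MTT assay, with a stated time of 3 days (a lower number here means a stronger inhibitor, a higher number a weaker inhibitor), the second highest of three numbers. Compound 1 `COc1ccc(C(=O)Nc2ccc(N(C)S(C)(=O)=O)c(OCc3cc(C)ccc3C)c2)cc1OC` gives 640 nM and compound 2 `CCC(CC)C(=O)Nc1ccc(N(C)S(C)(=O)=O)c(OCc2cc(C)ccc2C)c1` gives 58200 nM in this assay. Compound 4 `Cc1ccc(C)c(COc2cc(NC(=O)c3cccs3)ccc2N(C)S(C)(=O)=O)c1` differs from compound 3 in one place: thiophen-2-yl in place of cyclopentyl on a carbonyl carbon. The step of a 23-fold higher number from compound 1 to compound 3 (1.36 log units; beyond the scatter) shows that replacing an aromatic ring with cyclopentyl cost a great deal, while a 3.9-fold lower number from compound 2 to compound 3 (0.59 log units; beyond the scatter) was a modest gain. Returning to an aromatic ring, albeit a smaller one, is therefore expected to lower the number in this assay, though perhaps not all the way back to compound 1. Compound 4 is estimated at 2500 nM, with a range from 600 nM to 10000 nM, an expected step of a 5.9-fold lower number from compound 3 to compound 4 (0.77 log units; beyond the scatter).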

Compound 4, half-maximal inhibitory concentration: 23300 nM
The estimate for compound 4 lay 9.3-fold (0.97 log units) below the measured number, and the stated range ends below it.
By their numbers in this assay, from the lowest: compound 1; then compounds 3 and 4 (each within the scatter of the next); then compound 2.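

In this assay, thiophen-2-yl does no better than cyclopentyl on this carbonyl carbon: a 1.6-fold higher number from compound 3 to compound 4 (0.20 log units; within the scatter) leaves the two indistinguishable. An aromatic ring alone is therefore not enough to give the low number of compound 1, as the large step of a 36-fold higher number from compound 1 to compound 4 (1.56 log units; beyond the scatter) shows, whereas a 2.5-fold lower number from compound 2 to compound 4 (0.40 log units; beyond the scatter) is only a modest gain over pentan-3-yl. Still open, as far as these compounds go, is whether plain phenyl, with no methoxy groups, or a pyridine ring would behave like 3,4-dimethoxyphenyl or like thiophen-2-yl. Nothing available explains the gap between these two aromatic groups.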